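A few compounds are considered here, and "the series" means these few. Any claim that something is new, unique, unknown or untested is made for them only; others in the source may bear on it.

In a functional assay on HeLa cells (Homo sapiens) for cytotoxicity, read by MTT assay (on this read-out lower numbers stand for stronger inhibition and higher numbers for weaker inhibition), compound 1 `O=C1CC(CCc2ccccc2)SS1` gives 258000 nM while compound 2 `CC(C)(C)[Si](C)(C)O[C@@H]1[C@H](O[Si](C)(C)C(C)(C)C)[C@@H](C2CC(=O)S[S+]2[O-])O[C@H]1n1ccc(=O)[nH]c1=O` gives 3680 nM and compound 3 `O=C1CC([C@H]2O[C@@H](n3ccc(=O)[nH]c3=O)[C@H](O)[C@@H]2O)SS1` gives 62200 nM on the same read-out. Compound 3 is thus the second highest of the three numbers, lower than compound 1 and higher than compound 2, with both gaps beyond the scatter. Compound 4 `O=C1CC([C@H]2O[C@@H](n3ccc(=O)[nH]c3=O)[C@H](O)[C@@H]2O)[S+]([O-])S1` differs from compound 3 through a group of 7 heavy atoms (3 carbon, 2 oxygen, 2 sulfur; one five-membered non-aromatic ring with 2 hetero atoms) in place of a group of 6 heavy atoms (3 carbon, 1 oxygen, 2 sulfur; one five-membered non-aromatic ring with 2 hetero atoms), on a saturated ring carbon next to the ring oxygen. Going by the values given here, no measured step isolates this change. The entering group also stands in compound 2 at 3680 nM and on that ground the step of a 2.8-fold lower number from compound 3 to compound 4 (0.45 log units; beyond the scatter) is expected, a moderate fall beyond the scatter. Compound 4 is estimated at 22000 nM with an expected range from 6000 nM to 80000 nM in this assay.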

Compound 4, half-maximal inhibitory concentration: 50700 nM
Compound 4: middle estimate off by 2.3-fold (0.36 log units), on the low side; the range from low to high includes it.
By their numbers in this assay, from the lowest: compound 2; then compounds 4 and 3 (each within the scatter of the next); then compound 1.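

In this assay, placing the group of 7 heavy atoms on a saturated ring carbon next to the ring oxygen, in place of the group of 6 heavy atoms, gives a 1.2-fold lower number from compound 3 to compound 4 (0.09 log units; within the scatter) and so does not separate the two compounds. At this position and on this core, with its two hydroxy groups, the read-out therefore does not distinguish the two five-membered rings. Nothing measured here offers an explanation for this result.

The compounds shown leave open how an amine or a carboxylic acid would read on this ring carbon. They also leave open whether the same exchange would give a similar result on a different core.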